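Exchanging One Five-Membered Aromatic Substituent for Another

A few compounds are considered here, and "the series" means these few. Any claim that something is new, unique, unknown or untested is made for them only; others in the source may bear on it.

In a functional assay on MDA-MB-231 cells (Homo sapiens) for antiproliferative activity, read by MTT assay, with a stated time of 48 h (a higher number here means a weaker inhibitor, a lower number a stronger inhibitor), compound 1 `C=CS(=O)(=O)N1CCN(c2ncnc3sc(-c4ccccc4)cc23)CC1` gives 54200 nM and compound 2 `C=CS(=O)(=O)N1CCN(c2ncnc3sc(-c4ccc(OC)cc4)cc23)CC1` gives 29900 nM, a gap within the scatter. Compound 3 `C=CS(=O)(=O)N1CCN(c2ncnc3sc(-c4cn(C)nc4C(F)(F)F)cc23)CC1` stands lowest of the three at 10400 nM. Compound 4 `C=CS(=O)(=O)N1CCN(c2ncnc3sc(-c4c(C)noc4C)cc23)CC1` differs from compound 3 at one place, on an aromatic carbon next to the ring sulfur: 3,5-dimethyl-1,2-oxazol-4-yl in place of 1-methyl-3-(trifluoromethyl)-1H-pyrazol-4-yl on an aromatic carbon. Among the compounds with values here, no measured step makes this exact exchange. The closest evidence is two modest steps at the same place, a 5.2-fold lower number from compound 1 to compound 3 (0.72 log units; beyond the scatter) and a 2.9-fold lower number from compound 2 to compound 3 (0.46 log units; beyond the scatter), so a small upward move or none beyond the scatter is expected. The expected change is a 1.6-fold higher number from compound 3 to compound 4 (0.21 log units; within the scatter). Compound 4 is estimated at 17000 nM, within an expected range of 7000 nM to 45000 nM.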

Compound 4, half-maximal inhibitory concentration: 28200 nM
Compound 4: the middle estimate sits 1.7-fold (0.22 log units) below what was measured, within the range that was stated.
By their numbers in this assay, from the lowest: compound 3; then compounds 4, 2 and 1 (each within the scatter of the next).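

In this assay, exchanging the two five-membered aromatic substituents on the aromatic carbon next to the ring sulfur is not neutral (a 2.7-fold higher number from compound 3 to compound 4 (0.43 log units; beyond the scatter)), so a shared ring size does not make them interchangeable here. The 3,5-dimethyl-1,2-oxazol-4-yl group instead stays within the scatter of 4-methoxyphenyl (a 1.1-fold lower number from compound 2 to compound 4 (0.03 log units; within the scatter)) and phenyl (a 1.9-fold lower number from compound 1 to compound 4 (0.28 log units; within the scatter)). Nothing available explains this difference. The compounds shown leave open whether the trifluoromethyl group, the ring nitrogens or the methyl groups account for the step. They also leave open how a 1-methyl-1H-pyrazol-4-yl group or an amine-bearing ring would read at this place.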